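A few compounds are considered here, and "the series" means these few. Any claim that something is new, unique, unknown or untested is made for them only; others in the source may bear on it.

Compound 2 `C[C@@H]1CN(c2sc(C(F)(F)F)nc2-c2nc3ccccc3[nH]2)CCN1C(=O)Cn1cnc2cccnc21` gives 1.6 nM in a functional assay on CHO-K1 cells for antagonist activity at C-X-C chemokine receptor type 3 (Homo sapiens), read by FLIPR, with a stated time of 10 min (on this read-out lower numbers stand for stronger inhibition and higher numbers for weaker inhibition), the lowest of the two numbers in hand. Going by the values given here, compound 1 `C[C@@H]1CN(c2sc(CO)nc2-c2nc3ccccc3[nH]2)CCN1C(=O)Cn1cnc2cccnc21` gives 171 nM in this assay, and the single measured step, a 110-fold lower number from compound 1 to compound 2 (2.03 log units; beyond the scatter), concerns a change at a different position of the shared core. Compound 3 `COc1ccc(-c2nc(C(F)(F)F)sc2N2CCN(C(=O)Cn3cnc4cccnc43)[C@H](C)C2)cc1` is not yet measured. It differs from compound 2 by 4-methoxyphenyl in place of 1H-benzimidazol-2-yl on an aromatic carbon. Among the compounds with values here, no measured step touches this position, so the step from compound 1 to compound 2 offers no direct guide, beyond showing that a single change on this core can move the number a great deal. The group that leaves is larger than the group that enters and carries the only hydrogen-bond donor of the two. With no anchor, the expectation for compound 3 is a higher number, with wide uncertainty, the expected step being a 63-fold higher number from compound 2 to compound 3 (1.80 log units; beyond the scatter). Compound 3 is estimated at 100 nM, within a range from 10 nM to 1500 nM.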

Compound 3, half-maximal inhibitory concentration: 13 nM
Estimate against measurement, compound 3: 7.7-fold (0.89 log units) above; the range from low to high includes it.
By their numbers in this assay, from the lowest: compound 2; then compound 3; then compound 1.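

In this assay the position on the five-membered aromatic ring with 1 nitrogen and 1 sulfur accepts an exchange of 1H-benzimidazol-2-yl for 4-methoxyphenyl, with an 8.1-fold higher number from compound 2 to compound 3 (0.91 log units; beyond the scatter), so the number rises but stays far from lost. The entering group has 0 hydrogen-bond donors and no five-membered ring, yet compound 3 gives 13 nM, so neither feature of the leaving group is required for a number of this order, although compound 2, which has both, stays lower. No measurement at hand accounts for this difference.

This single pair changes the donor, the ring count and the methoxy group together, so their shares in the step cannot be separated. From the compounds shown here alone, whether plain phenyl, 4-hydroxyphenyl or 4-aminophenyl at this position would come closer to compound 2 remains open.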